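Methyl to bromo: from compound 3 to compound 4

This account rests on a few compounds, and the source may have more. Where it says the series, first, only, none or still open, it means among the compounds named here.

Compound 1 `Cc1nc(COc2ccc(/C=C3\SC(=O)NC3=O)cc2)cs1`, compound 2 `O=C1NC(=O)/C(=C/c2ccc(OCc3csc(-c4ccccc4)n3)cc2)S1` and compound 3 `Cc1ccc(-c2nnc(SCCOc3ccc(/C=C4\SC(=O)NC4=O)cc3)[nH]2)cc1` share one core. In a functional assay on the whole organism (strain Wistar) with Rattus norvegicus as the target, with a stated time of 15 days, at a dose of 30 mg/kg by the oral route (on this read-out higher numbers stand for a stronger effect at the one dose given and lower numbers for a weaker effect), compound 1 gives 26.4%, compound 2 gives 40.3% and compound 3 gives 40.3%. Compound 3 is level with compound 2 at the digits shown, the two together the highest of the three, and it sits above compound 1 beyond the scatter. Among the compounds with values here, the one counted step is a number 13.9 percentage points higher from compound 1 to compound 2 (beyond the scatter). Compound 4 `O=C1NC(=O)/C(=C/c2ccc(OCCSc3nnc(-c4ccc(Br)cc4)[nH]3)cc2)S1` differs from compound 3 by bromo in place of methyl on an aromatic carbon, 4-methylphenyl to 4-bromophenyl. Within the data shown here, no measured step swaps one substituent of this phenyl for another, so that step offers no direct guide; with nothing pointing either way, a change within the scatter is expected, a number 0.3 percentage points lower from compound 3 to compound 4 (within the scatter). Compound 4 is estimated at 40%, range 27% to 53%, in this assay.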

Compound 4, a percentage reported as activity, at one dose (the size of the read-out at that dose, not a potency): 39.5%
For compound 4 the middle estimate is 0.5 percentage points above the measured one, and the stated range covers the measured number.
By their numbers in this assay, from the lowest: compound 1; then compounds 4, 2 and 3 (each within the scatter of the next).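

Bromo in place of methyl, 4-methylphenyl to 4-bromophenyl, gives a number 0.8 percentage points lower from compound 3 to compound 4 (within the scatter) in this assay; this is the first measured swap of one substituent for another on this phenyl, and at this place the read-out does not separate the two groups. No measurement on hand bears on why this is so.

Open, on these data alone, is whether an amine or a carboxylic acid at the same aromatic carbon would give a step beyond the scatter. A methoxy group there would test whether the flat result extends past these two small substituents.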